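This account rests on a few compounds, and the source may have more. Where it says the series, first, only, none or still open, it means among the compounds named here.

Going by the values given here, of the three compounds measured so far, compound 3 `CSc1c(C#N)c(N)c(C#N)c(C)c1-c1ccc(F)cc1` stands highest in an assay on isolated protein for inhibition of glucose-6-phosphatase catalytic subunit 1 (Homo sapiens), tested at 100 uM (a higher number here means more inhibition at the concentration tested (going by the name of the read-out), a lower number less inhibition), where compound 3 gives 41.8%. Compound 1 `COc1ccc(-c2c(C#N)c(N)c(C#N)c(SC)c2-c2ccc(F)cc2)cc1` gives 5.5%, and compound 2 `CSc1c(C#N)c(N)c(C#N)c(C)c1-c1ccccc1F` gives 8.2%. Both steps toward compound 3 are large: a number 36.3 percentage points higher from compound 1 to compound 3 (beyond the scatter) and a number 33.6 percentage points higher from compound 2 to compound 3 (beyond the scatter).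

Compound 4 `CSc1c(C#N)c(N)c(C#N)c(C)c1-c1ccc(C(F)(F)F)cc1` differs from compound 3 by trifluoromethyl in place of fluoro on an aromatic carbon. Among the compounds with values here, neither measured step changes the group on this carbon in that way, so no step bears directly on the change, and the two large steps seen concern other parts of the molecule. The step of a number 6.8 percentage points lower from compound 3 to compound 4 (within the scatter) is therefore expected to be modest, with no firm direction. The estimate for compound 4 in this assay is 35%, in a range from 12% to 58%.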

Compound 4, a percentage reported as inhibition, at one concentration (the size of the read-out at that concentration, not a potency): 14.4%
Compound 4: the middle estimate sits 20.6 percentage points above what was measured; the measured number falls inside the stated range.
By their numbers in this assay, from the lowest: compounds 1, 2 and 4 (each within the scatter of the next); then compound 3.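

In this assay, trifluoromethyl in place of fluoro on this aromatic carbon gives a number 27.4 percentage points lower from compound 3 to compound 4 (beyond the scatter). The earlier steps shown here changed where the fluoro sat or what stood elsewhere on the shared core, whereas this one shows that the number also depends on which group occupies this carbon, para to a large group. Nothing measured here accounts for the drop.

The compounds shown leave open whether chloro, methyl or an amine on this carbon would keep the number of compound 3 or move it. With only fluoro and trifluoromethyl compared here, no trend across groups at this carbon can yet be drawn.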